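The compounds below may be only part of what the source reports. "The series", "measured", "known", "first", "only" and "open" are said of these compounds alone.

Of the compounds shown here, two of a shared core have been measured. Compound 1 `Cc1cccc(C2(CNC(=O)Nc3c(C(C)C)cccc3C(C)C)CCCC2)c1` gives 15 nM in an assay on microsomes for inhibition of acyl-CoA:cholesterol acyltransferase (Oryctolagus cuniculus) (on this read-out lower numbers stand for stronger inhibition and higher numbers for weaker inhibition), and compound 2 `COc1ccc(C2(CNC(=O)Nc3c(C(C)C)cccc3C(C)C)CCCC2)cc1` gives 31 nM. For the measured compounds named here, compound 2 thus has the higher of the two numbers, the weaker inhibition, and the one step between them, a 2.1-fold higher number from compound 1 to compound 2 (0.32 log units; beyond the scatter), describes that difference. Compound 3 `CC(C)c1cccc(C(C)C)c1NC(=O)NCC1(c2ccccc2C(F)(F)F)CCCC1` has not yet been measured; it differs from compound 2 in one place, (2-(trifluoromethyl)phenyl in place of 4-methoxyphenyl on a saturated ring carbon). No measured step covers a change of this kind: the only step in hand swaps one substituted phenyl for another on the same saturated ring carbon and is modest in size, as shown by a 2.1-fold higher number from compound 1 to compound 2 (0.32 log units; beyond the scatter). That step shows the assay responds to such swaps, but it gives no direction for a trifluoromethyl group. The expectation for compound 3 is therefore a number close to that of compound 2, with a step of about a 1.2-fold lower number from compound 2 to compound 3 (0.09 log units; within the scatter) expected, which falls within the usual scatter. Compound 3 is estimated at 25 nM, with a range from 8 nM to 80 nM.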

Compound 3, half-maximal inhibitory concentration: 18 nM
Compound 3: the middle estimate sits 1.4-fold (0.14 log units) above what was measured; the range from low to high includes it.
By their numbers in this assay, from the lowest: compounds 1, 3 and 2 (each within the scatter of the next, the first and the last beyond it).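

In this assay, placing 2-(trifluoromethyl)phenyl on the saturated ring carbon gives two steps that both lie within the scatter (a 1.7-fold lower number from compound 2 to compound 3 (0.24 log units; within the scatter); a 1.2-fold higher number from compound 1 to compound 3 (0.08 log units; within the scatter)), so compound 3 cannot be told apart from either earlier compound. For the compounds shown here, this shows that a phenyl group at this position does not need the hydrogen-bond acceptor of the 4-methoxyphenyl group to stay in this range of numbers, even though the group entering has more heavy atoms than the one leaving, while compound 1 and compound 2 remain the only pair set apart beyond the scatter. No measurement in hand accounts for why these three groups give such similar numbers.

All three compounds carry a substituted phenyl group, and each has its substituent in a different place on that phenyl, so the effect of the substituent cannot be separated from the effect of where it sits; 4-(trifluoromethyl)phenyl would be one way to separate them. Also open, from the compounds shown here alone, is how far this position reaches beyond such groups, for example with an amine or a carboxylic acid on the phenyl, or with a longer carbon chain in place of the phenyl.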